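Swapping nitro for amino at the tolerated limit

This account rests on a few compounds, and the source may have more. Where it says the series, first, only, none or still open, it means among the compounds named here.

In an ADME assay on MT2 cells (Homo sapiens) for cytotoxicity, read by XTT assay, with a stated time of 4 days (a higher number here means that more compound is tolerated, a lower number that less compound is tolerated), compound 1 (`Cc1cc(/C=C/C#N)cc(C)c1Oc1ccc([N+](=O)[O-])c(Nc2ccc(C#N)cc2)c1`) gives only a limit (> 100000 nM) and no number. Compound 3 (`Cc1cc(/C=C/C#N)cc(C)c1Oc1ccc(N)c(Nc2ccc(C#N)cc2)c1`) differs from it by one change (amino in place of nitro on an aromatic carbon), amino in place of nitro on an aromatic carbon, ortho to a (4-cyanophenyl)amino group. Compound 2 (`Cc1cc(/C=C/C#N)cc(C)c1Oc1cc(Nc2ccc(C#N)cc2)c([N+](=O)[O-])cc1[N+](=O)[O-]`) gives 21700 nM in this assay as a true number. Going by the values given here, the only measured step (an at least 4.6-fold lower number from compound 1 to compound 2 (0.66 log units; beyond the scatter)) is nitro in place of hydrogen on an aromatic carbon, a different change, so it bears only loosely. A modest downward step in this assay is expected (an at least 3.3-fold lower number from compound 1 to compound 3 (0.52 log units; beyond the scatter)) on that single precedent. Compound 3 is estimated at 30000 nM (expected range 8000 nM to 100000 nM).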

Compound 3, half-maximal cytotoxic concentration: 8830 nM
The estimate for compound 3 lay 3.4-fold (0.53 log units) above the measured number; measured number inside the range.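

In this assay the position ortho to a (4-cyanophenyl)amino group proves sensitive, with amino in place of nitro giving an at least 11-fold lower number from compound 1 to compound 3 (1.05 log units; beyond the scatter). The earlier step showed only a nitro placed on a ring carbon that carried hydrogen, whereas this one shows that replacing the nitro already present also lowers the number. Compound 1 stands at a limit, so the step has no upper bound: the limit of > 100000 nM in this assay, at which 1 of the 3 values shown sits.

From the compounds shown here alone, what a hydroxyl or an acetamide would do at this position stays open. So does whether the lower number follows the arrival of amino or the loss of nitro.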